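A dichlorophenyl swap on the core of compound 1

A few compounds are considered here, and "the series" means these few. Any claim that something is new, unique, unknown or untested is made for them only; others in the source may bear on it.

Compound 1 `COc1ccc2nc(-c3c(C)cccc3C)cc([Se]c3ccccc3)c2c1` (26900 nM)
Compound 2 `CCOC(=O)c1cc(C#CCCO)c2cc(OC)ccc2n1` (123000 nM)
Compound 3 `CCOC(=O)c1cc([Se]c2ccc3cc(OC)ccc3c2)c2cc(Cl)ccc2n1` (29200 nM)

All three numbers come from a functional assay on Jurkat cells (Homo sapiens) for cytotoxicity, read by MTT assay, with a stated time of 24 h (a lower number here means that less compound is needed, a higher number that more compound is needed for the effect), and they fall into two groups. Compound 1 gives 26900 nM and compound 3 gives 29200 nM as two values within the scatter of each other. Compound 2 gives 123000 nM as a higher number, and its distance from compound 1 lies beyond the scatter.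

The next compound to be tested is compound 4 `COc1ccc2nc(-c3c(Cl)cccc3Cl)cc([Se]c3ccccc3)c2c1`, which keeps the core of compound 1. It carries 2,6-dichlorophenyl in place of 2,6-dimethylphenyl on an aromatic carbon next to the ring nitrogen (2,6-dichlorophenyl in place of 2,6-dimethylphenyl on an aromatic carbon). Within the data shown here, the measured set holds no pair of compounds that differ in one place, so no direct precedent for this exchange is available. The expectation therefore rests on compound 1 (26900 nM) alone, and the two groups exchanged have the same heavy-atom count. In this assay no step beyond the scatter is expected, in either direction. The estimated change is a 1.1-fold lower number from compound 1 to compound 4 (0.05 log units; within the scatter) and would stay within the scatter. For compound 4 the estimate is 24000 nM with 10000 nM to 60000 nM as the expected range.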

Compound 4, half-maximal effective concentration: 17000 nM
For compound 4 the middle estimate is 1.4-fold (0.15 log units) above the measured one; the measured number falls inside the stated range.
By their numbers in this assay, from the lowest: compounds 4, 1 and 3 (each within the scatter of the next); then compound 2.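

Among these compounds, the pair of compound 1 and compound 4 is the first in the set to differ in one place, and it gives a direct reading for the aromatic carbon next to the ring nitrogen. There, in this assay, 2,6-dichlorophenyl in place of 2,6-dimethylphenyl gives a 1.6-fold lower number from compound 1 to compound 4 (0.20 log units; within the scatter) and this step lies within the scatter, so the two groups cannot be told apart in this read-out, although they share the same heavy-atom count and differ in chlorine against carbon. No measurement of any other property accompanies this pair, so the result stands without an explanation.

Going by these compounds, whether an amine or a carboxylic acid on this carbon, in place of the substituted phenyl ring, would give a step beyond the scatter stays open, since both groups seen here are 2,6-disubstituted phenyl rings. Compound 2 and compound 3 differ from this pair in more than one place, so what the rest of the core contributes also remains unresolved.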